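Three Ureas at the Edge of Activity, and a Fourth

The source may report more compounds than this note shows. Statements on the series, on what has been measured and on what is new or still open speak of the compounds shown alone.

Compound 1 `COc1ccccc1NC(=O)Nc1cccc(CNc2ncnc3ccccc23)c1`: 39300 nM
Compound 2 `O=C(Nc1ccc(F)cc1)Nc1cccc(CNc2ncnc3ccccc23)c1`: 44300 nM
Compound 3 `O=C(Nc1cccc(CNc2ncnc3ccccc23)c1)Nc1ccccc1Cl`: > 50000 nM

The three measured compounds share one core and differ only in the aryl group on the urea nitrogen. In a functional assay on MGC-803 cells (Homo sapiens) for antiproliferative activity, read by MTT assay (on this read-out lower numbers stand for stronger inhibition and higher numbers for weaker inhibition), compound 1 gives 39300 nM and compound 2 gives 44300 nM; the step of a 1.1-fold higher number from compound 1 to compound 2 (0.05 log units; within the scatter) lies within the scatter. For compound 3 this assay reports only a limit, > 50000 nM, which is a limit and not a number (the limit of > 50000 nM in this assay, at which 1 of the 3 values shown sits). The steps of an at least 1.2-fold higher number from compound 1 to compound 3 (0.10 log units; that floor lies within the scatter) and an at least 1.1-fold higher number from compound 2 to compound 3 (0.05 log units; that floor lies within the scatter) therefore have floors that also lie within the scatter.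

Compound 4 `O=C(Nc1cccc(Cl)c1)Nc1cccc(CNc2ncnc3ccccc23)c1` has not yet been measured. It differs from compound 3 by 3-chlorophenyl in place of 2-chlorophenyl on an amide-type nitrogen. The measured steps that bear on this change, all aryl swaps on the same nitrogen, were each within the scatter, so the account expects no step beyond the scatter here either, giving an at least 1.1-fold lower number from compound 3 to compound 4 (0.04 log units; that floor lies within the scatter) as the expected change. Compound 4 is estimated at 45000 nM in this assay, within 22000 nM to 90000 nM.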

Compound 4, half-maximal inhibitory concentration: 19200 nM
Estimate against measurement, compound 4: 2.3-fold (0.37 log units) above, and the stated range ends above it.
By their numbers in this assay, from the lowest: compound 4; then compounds 1 and 2 (each within the scatter of the next). At a limit, above all of these: compound 3.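

In this assay, the aryl group on the amide-type nitrogen now makes a difference: the swap of 2-chlorophenyl for 3-chlorophenyl gives an at least 2.6-fold lower number from compound 3 to compound 4 (0.41 log units; beyond the scatter), so two groups with the same atoms, joined differently, are told apart where every earlier swap stayed within the scatter. The other two ureas show the same separation, with a 2.3-fold lower number from compound 2 to compound 4 (0.36 log units; beyond the scatter) and a 2.0-fold lower number from compound 1 to compound 4 (0.31 log units; beyond the scatter). The step from compound 3 is only a floor, since compound 3 stands at a limit: the limit of > 50000 nM in this assay, at which 1 of the 4 values shown sits.

The compounds shown leave open whether 3-bromophenyl or 3-methoxyphenyl on this nitrogen would read like 3-chlorophenyl, and where 4-chlorophenyl would fall. They also give no cause for the step.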